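The source may report more compounds than this note shows. Statements on the series, on what has been measured and on what is new or still open speak of the compounds shown alone.

In an ADME assay on BJ cells (Homo sapiens), read by MTT assay, with a stated time of 72 h (a lower number here means a stronger inhibitor, a higher number a weaker inhibitor), compound 1 (`Cc1nc(N)c2c(-c3ccco3)cn([C@@H]3O[C@H](CO)[C@@H](O)[C@H]3O)c2n1`) gives > 100000 nM as a limit and not a number. Compound 2 (`Cc1nc(N)c2c(-c3ccoc3)cn([C@@H]3O[C@H](CO)[C@@H](O)[C@H]3O)c2n1`) gives > 100000 nM which is also a limit. Compound 3 (`Cc1nc(N)c2c(-c3cccs3)cn([C@@H]3O[C@H](CO)[C@@H](O)[C@H]3O)c2n1`) gives > 100000 nM as a limit too, so its standing is known only as a limit. Among the compounds with values here, the series so far is the limit of > 100000 nM in this assay, at which 3 of the 3 values shown sit, with no number to rank. Compound 4 (`Cc1nc(N)c2c(-c3ccsc3)cn([C@@H]3O[C@H](CO)[C@@H](O)[C@H]3O)c2n1`) differs from compound 3 in one place: thiophen-3-yl in place of thiophen-2-yl on an aromatic carbon on an aromatic carbon. The closest parallel is a step that the two limits leave unreadable from compound 1 to compound 2 and the other ring swaps are a step that the two limits leave unreadable from compound 1 to compound 3 and a step that the two limits leave unreadable from compound 2 to compound 3 so none of them gives a size. In this assay the expected a number no higher from compound 3 to compound 4 (the limit leaves the size open) has no direction and no size beyond the scatter. Compound 4 is estimated at 100000 nM with a range of 50000 nM to 200000 nM and is expected to read most likely as a limit again.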

Compound 4, half-maximal inhibitory concentration: > 100000 nM
Compound 4: a limit, no number (the forecaster's own chance of this, stated with the estimate: 90%); the middle value lies on the limit itself.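

No step from compound 1, compound 2 or compound 3 to compound 4 can be read, because all of these values are limits: the limit of > 100000 nM in this assay, at which 4 of the 4 values shown sit.

The compounds shown leave open how compound 1, compound 2, compound 3 and compound 4 rank against one another.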